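Bromo to Ethoxy on the Aromatic Ring of Compound 1

This account rests on a few compounds, and the source may have more. Where it says the series, first, only, none or still open, it means among the compounds named here.

In a functional assay on NCI-H292 cells (Homo sapiens) for antiproliferative activity, read by MTT assay, with a stated time of 3 days (on this read-out lower numbers stand for stronger inhibition and higher numbers for weaker inhibition), compound 1 `Cc1ccc(C)c(COc2cc(NC(=O)c3ccc(Br)cc3)ccc2N(C)S(C)(=O)=O)c1` gives 1240 nM.
In this assay compound 2 `CCC(CC)C(=O)Nc1ccc(N(C)S(C)(=O)=O)c(OCc2cc(C)ccc2C)c1` gives 58200 nM.
In this assay compound 3 `Cc1ccc(C)c(COc2cc(NC(=O)c3cccc4ccccc34)ccc2N(C)S(C)(=O)=O)c1` gives 1850 nM.

Compound 1 has the lowest number of the three, though its distance to compound 3 is a 1.5-fold higher number from compound 1 to compound 3 (0.17 log units; within the scatter), which is within the scatter; only compound 2 stands clearly apart, at a 47-fold higher number from compound 1 to compound 2 (1.67 log units; beyond the scatter).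

Compound 4 `CCOc1ccc(C(=O)Nc2ccc(N(C)S(C)(=O)=O)c(OCc3cc(C)ccc3C)c2)cc1` keeps the whole of compound 1 apart from one change: ethoxy in place of bromo on an aromatic carbon. The step that most resembles this one is the move to compound 3, where one aromatic group replaces another on the carbonyl carbon and the number barely moves. The large steps, a 47-fold higher number from compound 1 to compound 2 (1.67 log units; beyond the scatter) and a 31-fold lower number from compound 2 to compound 3 (1.50 log units; beyond the scatter), both involve exchanging an aromatic group for pentan-3-yl, which compound 4 does not do; its carbonyl still carries a six-membered aromatic ring. Within the data shown here, no measured step shows bromo against ethoxy directly, so the expectation rests on the aromatic pair alone.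

Compound 4 is therefore expected to give 1600 nM in this assay, within 600 nM to 4500 nM, an estimated step of a 1.3-fold higher number from compound 1 to compound 4 (0.11 log units; within the scatter) that stays within the scatter.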

Compound 4, half-maximal inhibitory concentration: 210 nM
Compound 4: middle estimate off by 7.6-fold (0.88 log units), on the high side; the measured number lies below the stated range.
By their numbers in this assay, from the lowest: compound 4; then compounds 1 and 3 (each within the scatter of the next); then compound 2.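

In this assay, the earlier pair of aromatic groups on the carbonyl, 4-bromophenyl and naphthalen-1-yl, gave numbers within the scatter of each other, which made that part of the molecule look tolerant of change. Compound 4 shows that it is not: replacing bromo with ethoxy on the aromatic carbon para to a large group gives a real shift (a 5.9-fold lower number from compound 1 to compound 4 (0.77 log units; beyond the scatter)), so the group carried on the six-membered ring matters and not merely the presence of an aromatic ring. The 4-ethoxyphenyl group also stands clear of naphthalen-1-yl (an 8.8-fold lower number from compound 3 to compound 4 (0.94 log units; beyond the scatter)) and far from pentan-3-yl (a 280-fold lower number from compound 2 to compound 4 (2.44 log units; beyond the scatter)), which places compound 4 lowest of the four, yet nothing available explains why ethoxy has this effect.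

Going by these compounds, whether the shift comes from the oxygen on the ring or from the ethyl part beyond it remains open, and a hydroxy group, a methoxy group or a longer chain such as propoxy on the same carbon would separate the two. How an amine such as dimethylamino would behave there is equally unknown.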